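Trading a Phenyl for Chloro on the Shared Core

The source may report more compounds than this note shows. Statements on the series, on what has been measured and on what is new or still open speak of the compounds shown alone.

Compound 1 `FC(F)(F)c1nc2c(-c3ccccc3)cccc2c(-c2ccccc2)c1-c1ccccc1` carries three phenyl groups and a trifluoromethyl group on the shared core. In an assay for inhibition of ectonucleoside triphosphate diphosphohydrolase 8 (Homo sapiens), read by malachite green, with a stated time of 10 min (a lower number here means a stronger inhibitor, a higher number a weaker inhibitor), compound 1 reaches only the limit of the assay, > 300000 nM, so no number is known for it. Compound 2 `FC(F)(F)c1nc2c(-c3ccsc3)cccc2c(Cl)c1Br` bears a thienyl group, a chloro and a bromo on the same core. In this assay compound 2 likewise stops at the limit, > 300000 nM. Both results sit at the limit of > 300000 nM in this assay, at which 2 of the 2 values shown sit, and neither compound has a measured potency. Compound 3 `FC(F)(F)c1nc2c(-c3ccccc3)cccc2c(Cl)c1-c1ccccc1` differs from compound 1 in one place: chloro in place of phenyl on an aromatic carbon. Going by the values given here, no measured pair in this set shows what such a change does, so the expectation for compound 3 rests only on the limits of compound 1 and compound 2. Compound 3 is expected to remain at the limit of this assay as well, with an estimated value of 300000 nM, lying between 100000 nM and 1000000 nM. The estimated step of a number no higher from compound 1 to compound 3 (the limit leaves the size open) amounts to none beyond the scatter.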

Compound 3, half-maximal inhibitory concentration: > 300000 nM
Compound 3: a limit, no number; the forecaster's own chance of this, stated with the estimate: 85%; the middle value sits exactly at the limit.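

In this assay compound 3 gives > 300000 nM, which is a limit and not a number. Compound 1 also stands at a limit, so the step from compound 1 to compound 3 cannot be read. The compounds shown leave open what chloro in place of phenyl does to potency, and whether any compound on this core has a measurable potency: the limit of > 300000 nM in this assay, at which 3 of the 3 values shown sit.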